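The compounds below may be only part of what the source reports. "The series", "measured", "known", "first", "only" and "open" are said of these compounds alone.

The study follows two measured compounds and one that still awaits measurement in a functional assay on HeLa cells (Homo sapiens) for antiproliferative activity, with a stated time of 5 days; a lower number here means a stronger inhibitor, a higher number a weaker inhibitor. Compound 1 `O=C1C=CC2(C=C1)OCC(=O)N2c1nc(-c2ccc3ccccc3c2Br)nn1-c1ccccc1` gives 290 nM in this assay. Going by the values given here, compound 2 `Cc1ccc(-n2nc(-c3ccc4ccccc4c3)nc2N2C(=O)C(C)OC23C=CC(=O)C=C3)cc1` gives 530 nM in this assay, the higher of the two numbers so far; its nearest neighbour is compound 1, and the gap between the two lies within the scatter, so the two values show nothing that can be read as an order of potency.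

Compound 3 `CC1OC2(C=CC(=O)C=C2)N(c2nc(-c3ccc4ccccc4c3)nn2-c2ccc3ccccc3c2)C1=O` is built from compound 2 by a change in one place: naphthalen-2-yl in place of 4-methylphenyl on an aromatic nitrogen. The naphthalen-2-yl enters on an aromatic nitrogen of the five-membered aromatic ring with three nitrogens, where the 4-methylphenyl stood before.

Among the compounds with values here, no pair of measured compounds isolates this exchange, so no step of known size can be drawn on. With the two measured values sitting within the scatter of each other, the step from compound 2 to compound 3 is expected to be small, a 1.3-fold lower number from compound 2 to compound 3 (0.12 log units; within the scatter), and to stay within the scatter in either direction. For compound 3 the estimated value is 400 nM, in a range from 150 nM to 1100 nM.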

Compound 3, half-maximal inhibitory concentration: 300 nM
Compound 3: middle estimate off by 1.3-fold (0.12 log units), on the high side, within the range that was stated.
By their numbers in this assay, from the lowest: compounds 1, 3 and 2 (each within the scatter of the next).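

Across the aromatic nitrogen of the five-membered aromatic ring with 3 nitrogen, the exchange of 4-methylphenyl for naphthalen-2-yl gives the first step that can be read directly in this assay, and it comes to a 1.8-fold lower number from compound 2 to compound 3 (0.25 log units; within the scatter). At this position, therefore, a group of 10 heavy atoms with 2 six-membered aromatic rings of carbon only, standing where one of 7 heavy atoms with a single such ring stood, leaves the number within the scatter, so compound 2 and compound 3 cannot be put in order. No measurement of any property of these two groups accompanies the result, and the step stands without an explanation.

The compounds shown leave open whether this aromatic nitrogen would hold its number with something other than a carbon-only aromatic group, such as a short chain ending in an amine or a carboxylic acid, since every group seen there so far is of that one kind. Compound 1 differs from compound 2 and compound 3 in more than one place, so its steps to them cannot be read.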